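This account rests on a few compounds, and the source may have more. Where it says the series, first, only, none or still open, it means among the compounds named here.

Compound 3 `Clc1cnccc1-c1cc(-c2cnn(C3CCNCC3)c2)on1` gives 200 nM in an assay on isolated protein for positive allosteric modulation of Neuronal acetylcholine receptor; alpha4/beta2 (Homo sapiens) (on this read-out higher numbers stand for an effect only at larger amounts of compound and lower numbers for an effect already at smaller amounts), and stands highest of the three numbers; compound 1 `Clc1ccccc1-c1cc(-c2cnn(C3CCNCC3)c2)on1` gives 120 nM and compound 2 `Fc1cccc(Cl)c1-c1cc(-c2cnn(C3CCNCC3)c2)on1` gives 48 nM. The step of a 1.7-fold higher number from compound 1 to compound 3 (0.22 log units; within the scatter) lies within the scatter, whereas a 4.2-fold higher number from compound 2 to compound 3 (0.62 log units; beyond the scatter) lies beyond it; the step of a 2.5-fold lower number from compound 1 to compound 2 (0.40 log units; beyond the scatter) concerns the fluoro addition alone. Compound 4 `Clc1sccc1-c1cc(-c2cnn(C3CCNCC3)c2)on1` carries 2-chlorothiophen-3-yl in place of 3-chloropyridin-4-yl on an aromatic carbon. Within the data shown here, no measured step exchanges this group for a five-membered ring; the nearest guide is a 1.7-fold higher number from compound 1 to compound 3 (0.22 log units; within the scatter), which stayed within the scatter. A small movement, not beyond the scatter, is therefore expected for compound 4, with a 1.5-fold lower number from compound 3 to compound 4 (0.19 log units; within the scatter) as the expected step. Compound 4 is estimated at 130 nM, with a range from 50 nM to 350 nM.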

Compound 4, half-maximal effective concentration: 130 nM
The estimate for compound 4 equals the measured number at the digits printed, and the stated range covers the measured number.
By their numbers in this assay, from the lowest: compound 2; then compounds 1, 4 and 3 (each within the scatter of the next).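

The aromatic carbon next to the ring nitrogen accepts a five-membered aromatic ring as readily as a six-membered one: 2-chlorothiophen-3-yl gives a 1.5-fold lower number from compound 3 to compound 4 (0.19 log units; within the scatter) and a 1.1-fold higher number from compound 1 to compound 4 (0.03 log units; within the scatter), so compounds 1, 3 and 4 cannot be separated. Only the 2-chloro-6-fluorophenyl group stands apart, with a 2.7-fold higher number from compound 2 to compound 4 (0.43 log units; beyond the scatter). Nothing at hand accounts for these results.

From the compounds shown here alone, whether a methyl or a nitrile could replace the chlorine on 2-chlorothiophen-3-yl remains open. So does whether a fluoro on the 3-chloropyridin-4-yl group would repeat a 2.5-fold lower number from compound 1 to compound 2 (0.40 log units; beyond the scatter).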